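From compound 3 to compound 4: one group exchanged

This account rests on a few compounds, and the source may have more. Where it says the series, first, only, none or still open, it means among the compounds named here.

compound 1 `COc1cc(/C=C/c2ccc(C3=C(c4ccc(O)cc4)C4CC(S(=O)(=O)Oc5cccc(OC)c5)C3O4)cc2)cc(OC)c1` at 77100 nM
compound 2 `O=S(=O)(Oc1ccc(F)cc1)C1CC2OC1C(c1ccc(/C=C/c3cc(O)cc(O)c3)cc1)=C2c1ccc(O)cc1` at 13100 nM
compound 3 `Cc1ccccc1OS(=O)(=O)C1CC2OC1C(c1ccc(/C=C/c3cc(O)cc(O)c3)cc1)=C2c1ccc(O)cc1` at 55800 nM

In a functional assay on MCF7 cells (Homo sapiens) for antiproliferative activity, read by MTT assay, with a stated time of 72 h (a higher number here means a weaker inhibitor, a lower number a stronger inhibitor), compound 3 gives 55800 nM and is level, within the scatter, with compound 1, while compound 2 stands clearly apart. Next comes compound 4 `O=S(=O)(Oc1ccc(O)cc1)C1CC2OC1C(c1ccc(/C=C/c3cc(O)cc(O)c3)cc1)=C2c1ccc(O)cc1`, with one change: 4-hydroxyphenyl in place of 2-methylphenyl on an oxygen. Within the data shown here, the one measured step that bears on this is a 4.3-fold higher number from compound 2 to compound 3 (0.63 log units; beyond the scatter) and it exchanges a group on that same oxygen. Compound 4 loses the 2-methylphenyl and gains a group named much like the 4-fluorophenyl of compound 2, so a partial return toward lower numbers is expected in this assay for this untested group. The expected step is a 2.5-fold lower number from compound 3 to compound 4 (0.40 log units; beyond the scatter) by this estimate. For compound 4 the estimated value is 22000 nM with 7000 nM to 65000 nM as its likely range.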

Compound 4, half-maximal inhibitory concentration: 14100 nM
For compound 4 the middle estimate is 1.6-fold (0.19 log units) above the measured one, within the range that was stated.
By their numbers in this assay, from the lowest: compounds 2 and 4 (each within the scatter of the next); then compounds 3 and 1 (each within the scatter of the next).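

Swapping 2-methylphenyl for 4-hydroxyphenyl on the oxygen bound to the sulfonyl sulfur gives a 4.0-fold lower number from compound 3 to compound 4 (0.60 log units; beyond the scatter) in this assay, so this position responds to the change. Hydroxy in place of fluoro on an aromatic carbon gives a 1.1-fold higher number from compound 2 to compound 4 (0.03 log units; within the scatter), which leaves these two groups level here. Nothing available explains either result. The compounds shown do not separate the effect of losing the methyl from that of gaining the hydroxy. 2-methylphenyl and 4-hydroxyphenyl differ in both. On these data alone, a plain phenyl, or an amine in place of the hydroxy, remains open.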